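The source may report more compounds than this note shows. Statements on the series, on what has been measured and on what is new or still open speak of the compounds shown alone.

The measured compounds and their values in a functional assay for agonist activity at G protein-coupled receptor 88 (Homo sapiens), read by HTRF and cAMP accumulation; a higher number here means that more compound is needed for the effect, a lower number that less compound is needed:

Compound 1 `CC(C)C[C@@H](N)CN(C(=O)[C@@H]1C[C@H]1c1ccccc1)c1ccc(-c2ccccc2)cc1` gives 1.8 nM.
Compound 2 `CC[C@H](C)[C@H](N)CN(C(=O)[C@@H]1C[C@H]1c1cccs1)c1ccc(-c2ccccc2)cc1` gives 360 nM.
Compound 3 `CC(C)C[C@H](N)CN(C(=O)[C@@H]1C[C@H]1c1ccccc1)c1ccc(-c2cccnc2)cc1` gives 10000 nM.

Among these three, compound 3 has the highest number in this assay. Its nearest neighbour in value is compound 2, and the distance between them is already beyond the usual scatter; compound 1 lies still further away at the other end of the range, so compound 3 is clearly the least potent of the three measured compounds.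

Compound 4 `CC(C)C[C@H](N)CN(C(=O)[C@@H]1C[C@H]1c1ccccc1)c1ccc(-c2cccs2)cc1` is not yet measured. It is derived from compound 3 by a single change: thiophen-2-yl in place of pyridin-3-yl on an aromatic carbon, on an aromatic carbon of a six-membered aromatic ring of carbon only, para to a large group. For the measured compounds named here, no measured pair in this set isolates exactly this exchange, so the direction and size of the step in this assay can only be judged loosely from where compound 3 sits and from how widely the three measured values spread.

The expectation is that the step from compound 3 to compound 4 in this assay, a 3.3-fold lower number from compound 3 to compound 4 (0.52 log units; beyond the scatter), is a moderate move toward a lower number, beyond the scatter but well short of the gap that separates compound 3 from compound 1. Compound 4 is therefore estimated at 3000 nM, with a plausible range from 700 nM to 12000 nM.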

Compound 4, half-maximal effective concentration: 1500 nM
The estimate for compound 4 lay 2.0-fold (0.30 log units) above the measured number; measured number inside the range.
By their numbers in this assay, from the lowest: compound 1; then compound 2; then compound 4; then compound 3.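

In this assay, thiophen-2-yl in place of pyridin-3-yl on an aromatic carbon, para to a large group, gives the first step in this set that isolates a single change (a 6.7-fold lower number from compound 3 to compound 4 (0.82 log units; beyond the scatter)), so this position is shown to respond to the identity of the ring it carries. The step is modest, and compound 4 at 1500 nM still needs a large amount of compound for the effect, so this exchange alone does not bring the number down far. Nothing available explains the difference between the two rings, which differ in ring size and in hetero atom, with nitrogen leaving and sulfur entering.

With only this pair, the compounds shown leave open whether ring size or the identity of the hetero atom accounts for the step, a question that thiophen-3-yl, furan-2-yl or pyridin-4-yl at the same place could help to separate. They also leave open whether the same exchange would give a step of similar size on a core with a different configuration or a different side chain.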